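The compounds below may be only part of what the source reports. "The series", "measured", "known", "first", "only" and "open" are said of these compounds alone.

Compound 3 `Nc1ccc2cccc(OCC3CCCC3)c2n1` stands lowest of the two numbers in an assay on cells with melanin-concentrating hormone receptor 1 (Homo sapiens) as the target, read by radioligand binding (on this read-out lower numbers stand for stronger inhibition and higher numbers for weaker inhibition), where compound 3 gives 53 nM. Compound 2 `CC(C)Oc1cccc2ccc(N)nc12` gives 437 nM in this assay. Compound 1 `COCCOCCOc1cccc2ccc(N)nc12` reaches only a limit in this assay, reported as > 2000 nM, which is the limit of > 2000 nM in this assay, at which 1 of the 3 values shown sits.

Two measured steps lead into compound 3. The step of an 8.2-fold lower number from compound 2 to compound 3 (0.92 log units; beyond the scatter) came with cyclopentylmethyl in place of isopropyl on an oxygen on an aromatic ring. The step of an at least 37-fold lower number from compound 1 to compound 3 (1.57 log units; beyond the scatter) came with cyclopentyl in place of (2-methoxyethoxy)methyl on a saturated chain carbon bound to an oxygen on an aromatic ring.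

Compound 4 `CC1CC1COc1cccc2ccc(N)nc12` differs from compound 3 in that place: 2-methylcyclopropyl in place of cyclopentyl on a saturated chain carbon bound to an oxygen on an aromatic ring. The step of an 8.2-fold lower number from compound 2 to compound 3 (0.92 log units; beyond the scatter) bears most on it, since the isopropyl of compound 2 and the 2-methylcyclopropyl of compound 4 both fall between the smaller and larger groups tried, so a modest rise in number, near the edge of the scatter, is expected. Compound 4 is therefore expected to give 100 nM in this assay, with a range of 35 nM to 300 nM. The expected step is a 1.9-fold higher number from compound 3 to compound 4 (0.28 log units; within the scatter).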

Compound 4, half-maximal inhibitory concentration: 1640 nM
Compound 4: middle estimate off by 16-fold (1.21 log units), on the low side; measured number outside the range, above it.
By their numbers in this assay, from the lowest: compound 3; then compound 2; then compound 4. At a limit, above all of these: compound 1.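

In this assay, 2-methylcyclopropyl in place of cyclopentyl on a saturated chain carbon bound to an oxygen on an aromatic ring came with a 31-fold higher number from compound 3 to compound 4 (1.49 log units; beyond the scatter), so a carbon ring on this saturated chain carbon is not enough by itself: the three-membered ring with its methyl does not keep the low number seen with the five-membered ring. The (2-methylcyclopropyl)methyl group also falls behind the open isopropyl group, with a 3.8-fold higher number from compound 2 to compound 4 (0.57 log units; beyond the scatter), so the gain seen on going from isopropyl to cyclopentylmethyl does not extend to both ring-bearing groups shown. The remaining step is only a floor, with an at least 1.2-fold lower number from compound 1 to compound 4 (0.08 log units; that floor lies within the scatter) as its reading. Compound 1 stands at a limit: the limit of > 2000 nM in this assay, at which 1 of the 4 values shown sits.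

From the compounds shown here alone, what remains open is whether the loss follows the smaller ring or the methyl on it, a question that cyclopropyl and cyclohexyl on the same saturated chain carbon would address. Also open, going by these compounds, is how a chain ending in an amine would read in this assay.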